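The compounds below may be only part of what the source reports. "The series", "measured", "known", "first", "only" and "open" are said of these compounds alone.

Measured so far:
compound 1 `CCC(C)Oc1c(-c2cc(OC)c(OC)c(OC)c2)oc2ccccc2c1=O` — > 50000 nM
compound 2 `CCN(CC)CCCOc1c(-c2cc(OC)c(OC)c(OC)c2)oc2ccccc2c1=O` — > 50000 nM

In a functional assay on DU-145 cells (Homo sapiens) for antiproliferative activity, read by WST assay, with a stated time of 3 days (a lower number here means a stronger inhibitor, a higher number a weaker inhibitor), compound 1 reports only a limit, > 50000 nM. In this assay compound 2 likewise reports only a limit, > 50000 nM. Within the data shown here, the single step between them, a step that the two limits leave unreadable from compound 1 to compound 2, therefore cannot be read, and the only evidence is the limit of > 50000 nM in this assay, at which 2 of the 2 values shown sit.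

Compound 3 `CCCCN(CCCC)CCCCOc1c(-c2cc(OC)c(OC)c(OC)c2)oc2ccccc2c1=O` is the next compound, differing from compound 2 by (dibutylamino)methyl in place of diethylamino on a saturated chain carbon, three bonds along the chain from an oxygen on an aromatic ring. Among the measured compounds shown here, no measured step bears on this change, since the one step available is hidden by the two limits. With compound 2 at > 50000 nM, the expectation for compound 3 in this assay is that it remains near the same limit, with an estimated step that the limit leaves unreadable from compound 2 to compound 3 that is not resolvable against the scatter. Compound 3 is thus estimated at 60000 nM, within a range from 8000 nM to 300000 nM.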

Compound 3, half-maximal inhibitory concentration: 15300 nM
Estimate against measurement, compound 3: 3.9-fold (0.59 log units) above, and the stated range covers the measured number.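

In this assay this position proves able to move the read-out: putting (dibutylamino)methyl in place of diethylamino gives an at least 3.2-fold lower number from compound 2 to compound 3 (0.51 log units; beyond the scatter), and compound 3 is the only compound shown with a number rather than a limit. Among these compounds, the step from compound 1 to compound 2 cannot be read, so this is the first sign that the group on the oxygen matters. Its true size stays unknown, as compound 2 reports only a limit: the limit of > 50000 nM in this assay, at which 2 of the 3 values shown sit.

This one change lengthens the chain and enlarges the groups on the nitrogen together, and the compounds shown do not separate the two. As far as these compounds go, whether a diethylamino group on a longer chain, a dibutylamino group on a shorter chain, or a cyclic amine such as piperidine at the chain end would do the same remains open.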